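The compounds below may be only part of what the source reports. "The series", "measured", "known", "first", "only" and "open" are said of these compounds alone.

Compound 1 `Cc1ccc(OCCCCOc2ccc(C(=O)CC(C)(C)C)c(O)c2C)cc1C(=O)O` and compound 2 `Cc1c(OCCCCOc2ccc(C(=O)O)c(F)c2)ccc(C(=O)CC(C)(C)C)c1O` share one core and differ only in the aryl group sitting on an oxygen on a saturated carbon of the linker. In an assay for positive allosteric modulation of metabotropic glutamate receptor 2 (Rattus norvegicus) (on this read-out lower numbers stand for an effect already at smaller amounts and higher numbers for an effect only at larger amounts of compound), compound 1 gives 210 nM. In this assay, among the measured compounds shown here, compound 2 gives 80 nM, the lowest of the two numbers so far, with compound 1 as its only neighbour. For the measured compounds named here, the single measured step, a 2.6-fold lower number from compound 1 to compound 2 (0.42 log units; beyond the scatter), shows that exchanging the aryl group at this position moved the read-out by a modest amount. Compound 3 `COc1ccc(OCCCCOc2ccc(C(=O)CC(C)(C)C)c(O)c2C)cc1` alters the same position again: 4-methoxyphenyl in place of 4-carboxy-3-fluorophenyl on an oxygen on a saturated carbon. Going by the values given here, no measured pair removes the carboxylic acid; the step from compound 1 to compound 2 kept it on both sides, so it sets only the scale of an aryl swap and says nothing about dropping the acid. On that footing a shift toward higher numbers in this assay is expected for compound 3, of size a 10-fold higher number from compound 2 to compound 3 (1.00 log units; beyond the scatter), with wide uncertainty. The estimate for compound 3 in this assay is 800 nM, expected within 150 nM to 5000 nM.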

Compound 3, half-maximal effective concentration: > 10000 nM
Compound 3 gave a limit, no number (the forecaster's own chance of this, stated with the estimate: 15%); middle value at least 12-fold (1.09 log units) away from the limit.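

In this assay compound 3 gives > 10000 nM, which is a limit of the assay and not a number. Replacing either carboxy-bearing aryl group with 4-methoxyphenyl gives a change far larger than the earlier aryl swap, with both new steps being bounds rather than exact sizes: an at least 120-fold higher number from compound 2 to compound 3 (2.09 log units; beyond the scatter), and an at least 47-fold higher number from compound 1 to compound 3 (1.67 log units; beyond the scatter). The position on an oxygen on a saturated carbon is therefore not merely open to modest tuning, as a 2.6-fold lower number from compound 1 to compound 2 (0.42 log units; beyond the scatter) alone suggested: among the three compounds, the two with a carboxy-bearing aryl group give numbers, and compound 3, the one without it, gives only the limit.

Going by these compounds, the change in compound 3 removes the carboxylic acid and brings in a methoxy group in one step, so the separate contribution of each stays open, as does whether a tetrazole or a primary amide in place of the carboxylic acid would give a number in this assay. Compound 1 and compound 2 also differ in methyl, fluorine and the placement of the carboxy group, so what each of these contributes to their step remains unresolved.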